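The source may hold more compounds than are shown below. What is called first, only, known or untested is meant among the compounds shown, and "the series" means these compounds.

Compound 1 `CC(C)OC(=O)N1CCC(Oc2ncnc3c2CCN3c2ccc(C#N)cc2F)CC1` is the starting point here. Among the measured compounds shown here, in a functional assay on CHO-K1 cells for agonist activity at Glucose-dependent insulinotropic receptor (Homo sapiens), read by a luciferase reporter, with a stated time of 5 h (a higher number here means that more compound is needed for the effect, a lower number that less compound is needed), compound 1 gives 63.1 nM, the second highest of the three numbers measured so far. Its nearest neighbour is compound 3 `CC(C)c1noc(N2CCC(O)CC2)n1`, which in this assay gives 50.1 nM, a gap within the scatter, so no order can be drawn between the two. Furthest from it is compound 2 `CC(C)OC(=O)N1CCC(Oc2ncnc3c2CCN3c2ccc(-c3cccn3C)cc2F)CC1`, which in this assay gives 158 nM; the single measured step, a 2.5-fold higher number from compound 1 to compound 2 (0.40 log units; beyond the scatter), arises from 1-methyl-1H-pyrrol-2-yl in place of cyano on an aromatic carbon.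

Compound 4 `Cc1cc(S(C)(=O)=O)ccc1N1CCc2c(OC3CCN(C(=O)OC(C)C)CC3)ncnc21` has not yet been measured. It differs from compound 1 in one place: 2-methyl-4-(methylsulfonyl)phenyl in place of 4-cyano-2-fluorophenyl on a nitrogen on an aromatic ring in a ring. For the measured compounds named here, no measured step exchanges the whole aryl group on that nitrogen; the step from compound 1 to compound 2 alters only one substituent of the 4-cyano-2-fluorophenyl and was modest, so it bears on the present change only loosely, and compound 3 belongs to another scaffold. The writer therefore expects in this assay a step of a 1.1-fold higher number from compound 1 to compound 4 (0.05 log units; within the scatter), near the scatter in either direction. Compound 4 is accordingly estimated at 70 nM, between 20 nM and 250 nM.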

Compound 4, half-maximal effective concentration: 100 nM
Beside the measured number, compound 4's estimate is 1.4-fold (0.15 log units) below it; the range from low to high includes it.
By their numbers in this assay, from the lowest: compounds 3, 1, 4 and 2 (each within the scatter of the next, the first and the last beyond it).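

The exchange of the whole aryl group on the nitrogen gives a 1.6-fold higher number from compound 1 to compound 4 (0.20 log units; within the scatter) in this assay, so this position takes 2-methyl-4-(methylsulfonyl)phenyl in place of 4-cyano-2-fluorophenyl with no change that can be read, whereas the earlier step had altered only one substituent of that aryl group. The nitrile and the fluorine leave together here while the methyl and the methylsulfonyl enter together, and the result is one number for the whole exchange, not a separate reading for each group. Nothing measured here explains why the number holds across this exchange.

On these data alone, it remains open whether the methyl and the methylsulfonyl each matter alone, as a single exchange cannot separate them. As far as these compounds go, it is also open how this assay would respond to an amine or a carboxylic acid in place of the methylsulfonyl.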